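Amino in Place of Nitro on Two Different Cores

A few compounds are considered here, and "the series" means these few. Any claim that something is new, unique, unknown or untested is made for them only; others in the source may bear on it.

Three compounds have been measured in a functional assay on MDA-MB-231 cells (Homo sapiens) for antiproliferative activity, read by MTT assay, with a stated time of 72 h; on this read-out higher numbers stand for weaker inhibition and lower numbers for stronger inhibition:
compound 1 `COc1ccc(-n2ccnc2-c2cc(OC)c(OC)c(OC)c2)cc1[N+](=O)[O-]` gives 7500 nM
compound 2 `COc1ccc(-n2ccnc2-c2cc(OC)c(OC)c(OC)c2)cc1N` gives 1040 nM
compound 3 `COc1ccc(C(=O)Oc2cc(OC)c(OC)c(OC)c2)cc1[N+](=O)[O-]` gives only a limit of the assay, > 100000 nM

Compound 1 and compound 2 share one core and differ by amino in place of nitro on an aromatic carbon. That single change made a measured step of a 7.2-fold lower number from compound 1 to compound 2 (0.86 log units; beyond the scatter). Compound 3 carries a different core, and how the two cores differ is not broken down here. Compound 4 `COc1ccc(C(=O)Oc2cc(OC)c(OC)c(OC)c2)cc1N` stands to compound 3 as compound 2 stands to compound 1: the change is amino in place of nitro on an aromatic carbon, the same change at the same kind of place, so it appears twice among these four compounds.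

What compound 4 will do in this assay is expected to be a step of an at least 2.5-fold lower number from compound 3 to compound 4 (0.39 log units; beyond the scatter), set beside the earlier step of a 7.2-fold lower number from compound 1 to compound 2 (0.86 log units; beyond the scatter), an expectation that rests on compound 3 sitting at the limit of > 100000 nM in this assay, at which 1 of the 3 values shown sits, and so leaving no number from which the earlier step could be carried over exactly. Compound 4 is therefore estimated at 40000 nM, most plausibly between 8000 nM and 200000 nM.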

Compound 4, half-maximal inhibitory concentration: > 100000 nM
Compound 4: no number, only a limit (the forecaster's own chance of this, stated with the estimate: 45%); middle value at least 2.5-fold (0.39 log units) away from the limit.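

Going by these compounds alone, compound 3 and compound 4 both stop at a limit of the assay in this assay, so no step between them can be read: the limit of > 100000 nM in this assay, at which 2 of the 4 values shown sit. On these data alone, whether amino in place of nitro lowers the number on the core of compound 3, as it did on the core of compound 1, stays open.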